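The source may hold more compounds than are shown below. What is called first, only, known or untested is meant among the compounds shown, and "the series" means these compounds.

Compound 1, with the structure `Cc1c(O)ccc2c1[C@H](Cn1cc(-c3ccc(F)cc3)nn1)[C@@]13CC(=O)[C@@](C)(CC[C@@H]21)C3`, was tested in a functional assay on HL-60 cells (Homo sapiens) for cytotoxicity, read by MTT assay, with a stated time of 4 days (on this read-out lower numbers stand for stronger inhibition and higher numbers for weaker inhibition), and there compound 1 gives > 20000 nM, which is a limit of the assay rather than a measured number. Compound 2, with the structure `Cc1ccc(S(=O)(=O)Oc2ccc3c(c2C)[C@H](Cn2cc(-c4ccc(F)cc4)nn2)[C@@]24CC(=O)[C@@](C)(CC[C@@H]32)C4)cc1`, carries a (4-methylphenyl)sulfonyl in place of the hydrogen on an oxygen on an aromatic ring; in this assay compound 2 gives > 20000 nM, again a limit. Among the compounds with values here, the step that the two limits leave unreadable from compound 1 to compound 2 therefore cannot be sized, and it is the only measured step in this set, as the limit of > 20000 nM in this assay, at which 2 of the 2 values shown sit, shows. Compound 3, with the structure `COc1ccc(-c2cn(C[C@H]3c4c(ccc(O)c4C)[C@@H]4CC[C@@]5(C)C[C@]43CC5=O)nn2)cc1`, differs from compound 1 by methoxy in place of fluoro on an aromatic carbon. No measured step concerns that position, so nothing among these numbers indicates a step beyond the usual scatter in either direction. Compound 1 itself sits at the limit of this assay, and the expectation is that compound 3 stays close to it. The estimated step of a number no higher from compound 1 to compound 3 (the limit leaves the size open) is expected to be small. Compound 3 is thus expected to give about 20000 nM, within a range from 5000 nM to 60000 nM, most likely reported as a limit.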

Compound 3, half-maximal inhibitory concentration: > 20000 nM
Compound 3 gave a limit, no number; the forecaster's own chance of this, stated with the estimate: 75%; the middle value lies on the limit itself.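

In this assay compound 3 gives > 20000 nM, a limit and not a number. Within the data shown here, no step between compound 1 and compound 3 can be read, and the same holds for the earlier pair: the limit of > 20000 nM in this assay, at which 3 of the 3 values shown sit. The compounds shown leave open how much 4-methoxyphenyl in place of 4-fluorophenyl changes the activity, and what number any of the three compounds would give.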